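Fluoro to chloro swap in a small growth-inhibition series

The source may hold more compounds than are shown below. What is called first, only, known or untested is meant among the compounds shown, and "the series" means these compounds.

compound 1 (`Cc1c(CNCc2ccccc2)cc(-c2ccc(Cl)cc2)n1-c1ccc(Cl)cc1`): (99 ug/mL)
compound 2 (`Cc1cc(CNC2CCCCC2)c(C)n1-c1ccc(Cl)cc1`): (7.4 ug/mL)
compound 3 (`Cc1cc(CNCc2ccccc2)c(C)n1-c1ccc(F)cc1`): (28 ug/mL)

In an ADME assay on THP-1 cells (Homo sapiens) for cytotoxicity, read by trypan blue exclusion, with a stated time of 48 h (a higher number here means a weaker inhibitor of growth, a lower number a stronger inhibitor of growth), compound 3 stands in the middle of the three numbers, with a higher number for compound 1 and a lower number for compound 2, both gaps beyond the scatter.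

The next compound, compound 4 (`Cc1cc(CNCc2ccccc2)c(C)n1-c1ccc(Cl)cc1`), is compound 3 with chloro in place of fluoro on an aromatic carbon, para to a large group (chloro in place of fluoro on an aromatic carbon).

Within the data shown here, no two measured compounds differ in one place only, so the size of this swap has not been seen directly. The 4-chlorophenyl group occurs in compound 2 (7.4 ug/mL) and in compound 1 (99 ug/mL), whose numbers lie on either side of compound 3, so that group alone sets no level. Only a small shift towards a lower number is expected, within the scatter (a 1.3-fold lower number from compound 3 to compound 4 (0.10 log units; within the scatter)). The estimated value for compound 4 is 22 ug/mL, with an expected range from 8 ug/mL to 55 ug/mL.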

Compound 4, concentration for 50% growth inhibition: 7.2 ug/mL
Beside the measured number, compound 4's estimate is 3.1-fold (0.49 log units) above it; the whole stated range lies above it.
By their numbers in this assay, from the lowest: compounds 4 and 2 (each within the scatter of the next); then compound 3; then compound 1.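

In this assay, among these compounds, the para place on the aromatic ring proves sensitive to the halogen: 4-fluorophenyl to 4-chlorophenyl gives a 3.9-fold lower number from compound 3 to compound 4 (0.59 log units; beyond the scatter) in the first direct reading of this swap. With chloro in place, benzyl in place of cyclohexyl on the amine nitrogen gives a 1.0-fold lower number from compound 2 to compound 4 (0.01 log units; within the scatter) and does not separate these two amine substituents, whereas methyl in place of 4-chlorophenyl on an aromatic carbon gives a 14-fold lower number from compound 1 to compound 4 (1.14 log units; beyond the scatter) as the largest step in the series. No measurement bears on what lies behind these steps.

As far as these compounds go, whether the fluoro to chloro step carries over to the cyclohexyl amine remains open. From the compounds shown here alone, how bromo, methoxy or a nitrile would read at the same para place also remains open.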